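Notes on a bombesin receptor subtype-3 agonist series

The source may report more compounds than this note shows. Statements on the series, on what has been measured and on what is new or still open speak of the compounds shown alone.

Measured in an in vitro functional assay on cells for agonist activity at Bombesin receptor subtype-3 (Homo sapiens), read by luminescence and calcium flux; on this read-out higher numbers stand for an effect only at larger amounts of compound and lower numbers for an effect already at smaller amounts:
compound 1 `CCCCc1cnc(C(CCCC)Cc2ccc(-c3ccccc3C(=O)O)cc2)[nH]1` gives 2660 nM
compound 2 `CCCCc1cnc(CCc2ccc(-c3ccccc3C(=O)O)cc2)[nH]1` gives 2710 nM
compound 3 `CCCCc1cnc(CCCc2ccc(-c3ccccc3C(=O)O)cc2)[nH]1` gives 5600 nM

Compound 2 holds the second highest of the three numbers. Its neighbour is compound 1, and the step from compound 1 to compound 2 is a 1.0-fold higher number from compound 1 to compound 2 (0.01 log units; within the scatter). Compound 2 (2710 nM) and compound 3 (5600 nM) differ by more than the scatter, with compound 3 the higher of the two.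

The next compound, compound 4 `COc1cccc(Cc2cnc(CCc3ccc(-c4ccccc4C(=O)O)cc3)[nH]2)c1`, differs from compound 2 by 3-methoxyphenyl in place of propyl on a saturated chain carbon bound to an aromatic carbon. Within the data shown here, the only measured step touching that saturated chain carbon is the one from compound 1 to compound 2, which was a 1.0-fold higher number from compound 1 to compound 2 (0.01 log units; within the scatter); it shows that removing butyl there leaves the number unchanged, but no measured step brings in an aromatic ring at that place. With only this to go on, the step from compound 2 to compound 4 in this assay is expected to be a 1.1-fold lower number from compound 2 to compound 4 (0.04 log units; within the scatter), small in either direction. Compound 4 is therefore estimated at 2500 nM, within 700 nM to 9000 nM.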

Compound 4, half-maximal effective concentration: 4120 nM
Compound 4: the middle estimate sits 1.6-fold (0.22 log units) below what was measured; low and high end bracket the measured number.
By their numbers in this assay, from the lowest: compounds 1, 2, 4 and 3 (each within the scatter of the next, the first and the last beyond it).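

In this assay, 3-methoxyphenyl in place of propyl on a saturated chain carbon bound to an aromatic carbon gives a 1.5-fold higher number from compound 2 to compound 4 (0.18 log units; within the scatter). Among these compounds, compounds 1, 2 and 3 carry only butyl there, so compound 4 is the first to show that this place tolerates an aromatic ring: the group entering has 8 heavy atoms against 3 leaving, plus 1 hydrogen-bond acceptor, and the step stays within the scatter. No measured evidence accounts for this result.

A single substituted ring cannot separate the contribution of the phenyl ring from that of its methoxy group. Still open, going by these compounds, is how an unsubstituted phenyl, or a ring carrying an amine or a carboxylic acid in place of methoxy, would read at this place.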